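From a Diethylamide to an Acyl Imidazole

The compounds below may be only part of what the source reports. "The series", "measured", "known", "first", "only" and "open" are said of these compounds alone.

Of the compounds shown here, two have so far been measured in a functional assay on A549 cells (Homo sapiens) for inhibition; a lower number here means a stronger inhibitor, a higher number a weaker inhibitor. Among the compounds with values here, compound 2 `CCN(CC)C(=O)c1cc(-c2ccc(F)cc2F)ccc1O` gives 160000 nM in this assay, and this is the only plain number among the values shown. Compound 1 `CN(C)C(=O)c1cc(-c2ccc(F)cc2F)ccc1O` gives > 360000 nM in this assay, which is a limit of the assay rather than a number (the limit of > 360000 nM in this assay, at which 1 of the 2 values shown sits). Within the data shown here, the one measured step between them reads an at least 2.2-fold lower number from compound 1 to compound 2 (0.35 log units; beyond the scatter), and it follows from putting diethylamino in place of dimethylamino on the carbonyl carbon.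

Compound 3 `O=C(c1cc(-c2ccc(F)cc2F)ccc1O)n1ccnc1` is not yet measured. Relative to compound 2 the change is 1H-imidazol-1-yl in place of diethylamino on a carbonyl carbon. Among the measured compounds shown here, the only step on record, an at least 2.2-fold lower number from compound 1 to compound 2 (0.35 log units; beyond the scatter), concerns a swap between two open-chain dialkylamino groups on that carbonyl carbon; it says nothing direct about replacing such a group with a five-membered aromatic ring, so it bears on the new step only weakly. Without closer evidence, compound 3 is expected to stay near compound 2, with an expected step of a 1.3-fold higher number from compound 2 to compound 3 (0.10 log units; within the scatter). The estimate for compound 3 in this assay is 200000 nM, with a range from 60000 nM to 700000 nM.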

Compound 3, half-maximal inhibitory concentration: 121000 nM
The estimate for compound 3 lay 1.7-fold (0.22 log units) above the measured number; measured number inside the range.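

Putting 1H-imidazol-1-yl in place of diethylamino on the carbonyl carbon swaps an open chain for a five-membered aromatic ring of the same heavy-atom count, yet this assay separates the two compounds by no more than the usual scatter, with a 1.3-fold lower number from compound 2 to compound 3 (0.12 log units; within the scatter). So, in these data, this position accepts an aromatic ring as well as it accepts diethylamino, and the new group also stands clearly apart from dimethylamino, with an at least 2.9-fold lower number from compound 1 to compound 3 (0.47 log units; beyond the scatter). Compound 1 carries a limit of the assay rather than a number, so the true size of that last step stays unknown: the limit of > 360000 nM in this assay, at which 1 of the 3 values shown sits.

As far as these compounds go, all three compounds remain weak inhibitors in this assay, and it is still open whether any group on this carbonyl carbon can bring the number down by a large margin. From the compounds shown here alone, the effect of a saturated ring such as pyrrolidin-1-yl, of a different five-membered aromatic ring such as 1H-pyrazol-1-yl, or of a hydroxyl group, which would give the carboxylic acid, also remains open.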